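The source may report more compounds than this note shows. Statements on the series, on what has been measured and on what is new or still open speak of the compounds shown alone.

Working notes on the series.

Compound 1 `CCN1CCN(Cc2ccc(NC(=O)COc3ccc(-c4cccnc4)cc3)cc2C(F)(F)F)CC1` is the reference point. Among the measured compounds shown here, in an assay on cells for inhibition of MAP kinase-interacting serine/threonine-protein kinase 1 (Homo sapiens), read by mobility shift assay, with stated times of 10 min and 60 min (a lower number here means a stronger inhibitor, a higher number a weaker inhibitor), compound 1 gives 570 nM, the lowest of the two numbers so far. For the measured compounds named here, its only measured neighbour is compound 2 `CCC1CCN(Cc2ccc(NC(=O)COc3ccc(-c4cccnc4)cc3)cc2C(F)(F)F)CC1`, which in this assay gives 4510 nM; the step of a 7.9-fold higher number from compound 1 to compound 2 (0.90 log units; beyond the scatter) is beyond the scatter and goes to a weaker inhibitor. That step changes the amine on the benzylic carbon, not the linker between the amide and the aryl ether.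

Compound 3 `CCN1CCN(Cc2ccc(NC(=O)C(C)Oc3ccc(-c4cccnc4)cc3)cc2C(F)(F)F)CC1` has not been measured. It differs from compound 1 by methyl in place of hydrogen on a saturated chain carbon bound to a carbonyl carbon and an oxygen on an aromatic ring. Going by the values given here, no measured step touches this position, so the one step available, from compound 1 to compound 2, bears on it only as a sign that the series is sensitive to change at all and says nothing about direction here. Among the compounds with values here, with no directly relevant precedent, the expectation is a step not clearly beyond the scatter, a 1.3-fold higher number from compound 1 to compound 3 (0.12 log units; within the scatter). Compound 3 is therefore expected to give about 750 nM in this assay, estimated to lie between 250 nM and 2300 nM.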

Compound 3, half-maximal inhibitory concentration: > 10000 nM
Compound 3: no number, only a limit; the forecaster's own chance of this, stated with the estimate: 3%; middle value at least 13-fold (1.12 log units) away from the limit.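

Compound 3 gives no number in this assay, only a limit of the assay: the limit of > 10000 nM in this assay, at which 1 of the 3 values shown sits. The change is a single methyl in place of hydrogen on a saturated chain carbon bound to a carbonyl carbon and an oxygen on an aromatic ring, and it produces an at least 17-fold higher number from compound 1 to compound 3 (1.24 log units; beyond the scatter). Among the compounds shown here, until now the only reading of sensitivity came from the amine, with a 7.9-fold higher number from compound 1 to compound 2 (0.90 log units; beyond the scatter); this result shows that the linker carbon, which that step left untouched, is also sensitive, and that one added carbon here costs more in this assay than the exchange of the amine did.

From the compounds shown here alone, since the result is a limit, the true size of the loss stays unknown, and a single substituent cannot show whether the loss belongs to methyl alone or to any group other than hydrogen on this carbon. Fluorine, a hydroxyl or an ethyl group on the same carbon would separate those readings, and whether any of them keeps the activity of compound 1 remains open.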